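The compounds below may be only part of what the source reports. "The series", "measured", "known", "first", "only" and "open" are said of these compounds alone.

Measured compounds in an assay on HEK293 cells for displacement of a labelled ligand from NPC1-like intracellular cholesterol transporter 1 (Homo sapiens); on this read-out higher numbers stand for weaker inhibition and lower numbers for stronger inhibition:
- compound 1 `CC(C)(C)c1ccc(C(=O)N2CCC3(CC2)C(=O)N(CC(=O)N2CCN(S(C)(=O)=O)CC2)CN3c2ccccc2)cc1`: 19000 nM
- compound 2 `CC(C)(C)c1ccc(C(=O)N2CCC3(CC2)C(=O)N(CC(=O)N2CCCC(O)C2)CN3c2ccccc2)cc1`: 12200 nM
- compound 3 `CC(C)(C)c1ccc(C(=O)N2CCC3(CC2)C(=O)N(CC(=O)N2CCCCC2CCO)CN3c2ccccc2)cc1`: 6100 nM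

Compound 3 carries the lowest of the three numbers, but only a 3.1-fold lower number from compound 1 to compound 3 (0.49 log units; beyond the scatter) is beyond the scatter, whereas a 2.0-fold lower number from compound 2 to compound 3 (0.30 log units; within the scatter) is within it, as is a 1.6-fold lower number from compound 1 to compound 2 (0.19 log units; within the scatter).

Compound 4 `CC(C)(C)c1ccc(C(=O)N2CCC3(CC2)C(=O)N(CC(=O)N2CCCCC2CO)CN3c2ccccc2)cc1` differs from compound 3 by hydroxy in place of hydroxymethyl on a saturated chain carbon bound to a saturated ring carbon. Going by the values given here, the only step that bears on it is the exchange of ring substituents in a 2.0-fold lower number from compound 2 to compound 3 (0.30 log units; within the scatter), which stayed within the scatter; shortening the 2-hydroxyethyl chain to hydroxymethyl is a smaller change than that, so no step beyond the scatter is expected, with the number estimated to sit close to compound 3 or slightly higher, as a 1.3-fold higher number from compound 3 to compound 4 (0.12 log units; within the scatter). Compound 4 is therefore expected to give about 8000 nM, within 4000 nM to 16000 nM.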

Compound 4, half-maximal inhibitory concentration: 11800 nM
The estimate for compound 4 lay 1.5-fold (0.17 log units) below the measured number; low and high end bracket the measured number.
By their numbers in this assay, from the lowest: compounds 3, 4, 2 and 1 (each within the scatter of the next, the first and the last beyond it).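

At this position, going from 2-hydroxyethyl to hydroxymethyl on a saturated ring carbon leaves the two compounds unresolved in this assay (a 1.9-fold higher number from compound 3 to compound 4 (0.29 log units; within the scatter)). The 2-(hydroxymethyl)piperidin-1-yl group also stays within the scatter of both other groups on the carbonyl carbon (a 1.0-fold lower number from compound 2 to compound 4 (0.01 log units; within the scatter); a 1.6-fold lower number from compound 1 to compound 4 (0.21 log units; within the scatter)), whereas the 2-(2-hydroxyethyl)piperidin-1-yl group stood beyond it from the 4-(methylsulfonyl)piperazin-1-yl group. No measurement at hand accounts for these numbers.

As far as these compounds go, whether a longer chain, such as 3-hydroxypropyl, or an aminomethyl or carboxylic acid group at this position would separate from compound 3 remains open.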